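The source may hold more compounds than are shown below. What is called first, only, known or untested is meant among the compounds shown, and "the series" means these compounds.

Measured compounds:
Compound 1, `COc1cc(NC(C)CCCN2C(=O)[C@@H](C)N(C(=O)CN)C2(C)C)c2ncccc2c1`: 2.54
Compound 2, `COc1cc(NC(C)CCCN2C(=O)CN(C(=O)[C@H](N)CCSC)C2(C)C)c2ncccc2c1`: 2.94
Compound 3, `COc1cc(NC(C)CCCN2C(=O)CN(C(=O)CN)C2(C)C)c2ncccc2c1`: 2.19

All three share one core and differ in small groups on the saturated ring or on the carbon that carries the amine. In a physicochemical assay for lipophilicity, measured as octanol-water partition (a higher number here means a more lipophilic compound, a lower number a more polar compound), compound 3 gives 2.19, the lowest of the three numbers, with compound 1 nearest and compound 2 furthest away, both gaps beyond the scatter.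

Compound 4, `COc1cc(NC(C)CCCN2C(=O)CN(C(=O)[C@H](N)C(C)C)C2(C)C)c2ncccc2c1`, has not yet been measured in this assay. Its difference from compound 3 is isopropyl in place of hydrogen on a saturated chain carbon bound to an amine nitrogen and a carbonyl carbon.

Going by the values given here, two measured steps bear on this. a number 0.35 log units lower from compound 1 to compound 3 (beyond the scatter). a number 0.75 log units lower from compound 2 to compound 3 (beyond the scatter). Both show that taking carbon away lowers the number, and the second step concerns the very same place where the isopropyl now enters. Adding three carbon atoms there is therefore expected to raise the number by a modest step, about a number 0.71 log units higher from compound 3 to compound 4 (beyond the scatter), beyond the scatter. Compound 4 is thus estimated at 2.9, with a range from 2.5 to 3.3.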

Compound 4, partition coefficient: 2.93
Estimate against measurement, compound 4: 0.03 log units below, within the range that was stated.
By their numbers in this assay, from the lowest: compound 3; then compound 1; then compounds 4 and 2 (each within the scatter of the next).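

In this assay, isopropyl in place of hydrogen on the saturated chain carbon bound to an amine nitrogen and a carbonyl carbon gives a number 0.74 log units higher from compound 3 to compound 4 (beyond the scatter) and makes it the second group measured to lift the number above hydrogen at this place. Isopropyl in place of 2-(methylsulfanyl)ethyl at the same carbon gives a number 0.01 log units lower from compound 2 to compound 4 (within the scatter) and so leaves the two groups level here, although only one of them holds a sulfur atom. No measurement among these compounds offers an explanation for this match.

The compounds shown leave open whether a benzyl group or a carboxylic acid on this carbon would also raise the number. They also leave open whether the methyl on the saturated ring carbon of compound 1 would add to the isopropyl step if both stood on one compound.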